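One group exchanged on the amide-type nitrogen

This account rests on a few compounds, and the source may have more. Where it says the series, first, only, none or still open, it means among the compounds named here.

In a physicochemical assay for lipophilicity, at pH 7.4 (on this read-out lower numbers stand for lower lipophilicity and higher numbers for higher lipophilicity), compound 2 `O=C1Cc2cc(NC(=O)[C@H]3CCCN3C(=O)C3(c4cccc(Cl)c4)CCCC3)ccc2N1` gives 5. Compound 3 `O=C(Nc1ccc2[nH]ncc2n1)[C@H]1CCCN1C(=O)C1(c2ccc(Cl)cc2)CCC1` gives 4.7, within the scatter of compound 2, while compound 1 `O=C(Nc1ccc2[nH]ccc2n1)[C@H]1CCCN1C(=O)C1(c2cccc(Cl)c2)CCCC1` gives 5.9. Compound 4 `O=C(Nc1ccc2[nH]nnc2c1)[C@H]1CCCN1C(=O)C1(c2cccc(Cl)c2)CCCC1` differs from compound 2 in one group: a group of 9 heavy atoms (6 carbon, 3 nitrogen; one five-membered aromatic ring with 3 hetero atoms, one six-membered aromatic ring of carbon only) in place of a group of 10 heavy atoms (8 carbon, 1 nitrogen, 1 oxygen; one five-membered non-aromatic ring with 1 hetero atom, one six-membered aromatic ring of carbon only), on an amide-type nitrogen.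

For the measured compounds named here, the only measured step at this place is a number 0.90 log units lower from compound 1 to compound 2 (beyond the scatter). The group of compound 2 is the one that enters in that step and the one that leaves here, so that step bears directly on the change. Compound 1, at 5.9, carries a five-membered aromatic ring in this group, as compound 4 does, but the two groups are not the same. Going by the values given here, compound 3 also differs elsewhere, so it offers no clean step. Among the compounds with values here, no measurement yet covers the group entering here, so only part of the earlier size is expected to return, in the upward direction. The expected change is a number 0.20 log units higher from compound 2 to compound 4 (within the scatter). The estimate for compound 4 is 5.2, with an expected range from 4.6 to 5.8.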

Compound 4, distribution coefficient: 5.2
Compound 4: middle estimate and measured number agree at the digits printed, within the range that was stated.
By their numbers in this assay, from the lowest: compounds 3, 2 and 4 (each within the scatter of the next, the first and the last beyond it); then compound 1.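

With a third group now on the amide-type nitrogen over the same remainder, this assay gives a number 0.20 log units higher from compound 2 to compound 4 (within the scatter), so the exchange of the group with the five-membered non-aromatic ring for the one with the five-membered aromatic ring with 3 hetero atoms cannot be told apart from the scatter. Set against the group of compound 1, the same entering group gives a number 0.70 log units lower from compound 1 to compound 4 (beyond the scatter), so a five-membered aromatic ring in the group does not by itself keep the number at the level of compound 1. No measurement on hand accounts for either step.

Open, from the compounds shown here alone, is how a plain phenyl group or a group carrying a carboxylic acid would read on this nitrogen. Also open, going by these compounds, is whether these exchanges carry over to the core of compound 3.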